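This account rests on a few compounds, and the source may have more. Where it says the series, first, only, none or still open, it means among the compounds named here.

In an in vivo ADME assay on the whole organism (Cavia porcellus) (on this read-out higher numbers stand for a longer-lived compound and lower numbers for a shorter-lived compound), compound 1 `C/C=C/C(NC(=O)c1ccc(C(=N)N)cc1)C(C)(C)C(=O)N1CCC(CC(=O)O)CC1` gives 0.933 h and compound 2 `CCCCC(NC(=O)c1ccc(C(=N)N)cc1)C(C)(C)C(=O)N1CCC(CC(=O)O)CC1` gives 1.03 h, so compound 2 stands level with compound 1 within the scatter. Compound 3 `CCCCCC(NC(=O)c1ccc(C(=N)N)cc1)C(C)(C)C(=O)N1CCC(CC(=O)O)CC1` departs from compound 2 by methyl in place of hydrogen on a saturated chain carbon, five bonds along the chain from an amide-type nitrogen. Among the measured compounds shown here, the only measured step that bears on this change is a 1.1-fold higher number from compound 1 to compound 2 (0.04 log units; within the scatter), which also alters the chain and stays within the scatter. No step beyond the scatter is therefore expected in this assay, though a single small step is thin evidence. The expected step is a 1.0-fold higher number from compound 2 to compound 3 (0.01 log units; within the scatter). Compound 3 is estimated at 1.05 h, with an expected range of 0.6 h to 1.8 h.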

Compound 3, half-life: 0.517 h
Compound 3: middle estimate off by 2.0-fold (0.31 log units), on the high side; measured number below the stated range.
By their numbers in this assay, from the lowest: compounds 3, 1 and 2 (each within the scatter of the next).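

In this assay methyl in place of hydrogen, five bonds along the chain from the amide-type nitrogen, gives a 2.0-fold lower number from compound 2 to compound 3 (0.30 log units; within the scatter) and pentyl in place of prop-1-en-1-yl gives a 1.8-fold lower number from compound 1 to compound 3 (0.26 log units; within the scatter) and thus neither change moves the half-life beyond the scatter. At this position, prop-1-en-1-yl, butyl and pentyl therefore stand level within the scatter. No available evidence bears on this result.

Still open, as far as these compounds go, is whether a longer chain, a cyclohexyl ring or a chain ending in an amine at this position would give a step beyond the scatter.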